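The compounds below may be only part of what the source reports. "The series", "measured", "known", "first", "only" and "open" are said of these compounds alone.

Compound 1 `O=C(O)Cc1sc(C(c2ccc(F)cc2)c2ccc(F)cc2)nc1-c1ccoc1` gives 130 nM in an in vitro functional assay on HEK285-7 cells for antagonist activity at prostaglandin D2 receptor 2 (Homo sapiens), read by BRET and beta-arrestin recruitment; a lower number here means a stronger inhibitor, a higher number a weaker inhibitor.
Compound 2 `O=C(O)Cc1sc(C(c2ccccc2)c2ccccc2)nc1-c1ccc(F)c(F)c1` gives 43 nM in this assay.
Compound 3 `O=C(O)Cc1sc(C(c2ccccc2)c2ccc(F)c(F)c2)nc1-c1ccc(F)cc1` gives 64 nM in this assay.

Among these three, compound 1 has the highest number; compound 3 is nearest to it and compound 2 furthest, and both of those gaps lie beyond the scatter. Compound 4 `N#Cc1ccc(-c2nc(C(c3ccc(F)cc3)c3ccc(F)cc3)sc2CC(=O)O)cc1` has not yet been measured in this assay. It differs from compound 1 in one place: 4-cyanophenyl in place of furan-3-yl on an aromatic carbon. Going by the values given here, no measured pair shows this exact change, so the expectation rests only on the shared core and the three values above. Compound 4 is expected to give 60 nM, within 25 nM to 150 nM. That expectation amounts to a step of a 2.2-fold lower number from compound 1 to compound 4 (0.34 log units; beyond the scatter), a modest lowering of the number from compound 1, beyond the scatter but not far.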

Compound 4, half-maximal inhibitory concentration: 1500 nM
For compound 4 the middle estimate is 25-fold (1.40 log units) below the measured one, outside the stated range (above it).
By their numbers in this assay, from the lowest: compounds 2 and 3 (each within the scatter of the next); then compound 1; then compound 4.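

In this assay, going by these compounds alone, the change to 4-cyanophenyl in place of furan-3-yl brings a 12-fold higher number from compound 1 to compound 4 (1.06 log units; beyond the scatter) and so gives the first single-place reading at this position. It shows that, on the core of compound 1, the group on this aromatic carbon can shift the number by a large margin. Nothing measured here accounts for the step.

Open, from the compounds shown here alone, is whether the nitrile or the six-membered ring carries the step. An unsubstituted phenyl on the same core would separate the two.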